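This account rests on a few compounds, and the source may have more. Where it says the series, first, only, none or still open, it means among the compounds named here.

For the measured compounds named here, in a functional assay on SW 1116 cells (Homo sapiens) for antiproliferative activity, read by MTT assay, with a stated time of 24 h (on this read-out higher numbers stand for weaker inhibition and lower numbers for stronger inhibition), compound 1 `c1ccc(CSc2nnc(-c3ccc4c(c3)OCCO4)n2-c2ccccc2)cc1` gives 7930 nM and compound 2 `Cc1ccccc1CSc1nnc(-c2ccc3c(c2)OCCO3)n1-c1ccccc1` gives 12700 nM, so compound 2 stands within the scatter of compound 1, the only other number. Still unmeasured is compound 3 `Fc1ccccc1CSc1nnc(-c2ccc3c(c2)OCCO3)n1-c1ccccc1`, with the change fluoro in place of methyl on an aromatic carbon, ortho to a large group. Going by the values given here, the one measured step that bears on it is a 1.6-fold higher number from compound 1 to compound 2 (0.20 log units; within the scatter), which put that same methyl in place of hydrogen and stayed within the scatter. Among the compounds with values here, no measured compound carries fluoro, so the data give no direction for this swap, and no step beyond the scatter is expected. The expected step is a 1.3-fold lower number from compound 2 to compound 3 (0.13 log units; within the scatter). In this assay the estimate for compound 3 is 9500 nM, with an expected range of 4500 nM to 20000 nM.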

Compound 3, half-maximal inhibitory concentration: 13600 nM
Estimate against measurement, compound 3: 1.4-fold (0.16 log units) below; measured number inside the range.
By their numbers in this assay, from the lowest: compounds 1, 2 and 3 (each within the scatter of the next).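

Fluoro at this place, on an aromatic carbon ortho to a large group, gives a 1.1-fold higher number from compound 2 to compound 3 (0.03 log units; within the scatter) against methyl and a 1.7-fold higher number from compound 1 to compound 3 (0.23 log units; within the scatter) against hydrogen in this assay. With a 1.6-fold higher number from compound 1 to compound 2 (0.20 log units; within the scatter) already known, hydrogen, methyl and fluoro now form a set of three at one place with every pairwise step inside the scatter, so the 2-methylbenzyl to 2-fluorobenzyl swap does not separate these compounds, and neither substituent separates from the unsubstituted benzyl of compound 1. Nothing available explains this flat result.

As far as these compounds go, whether an amine, a carboxylic acid or a longer chain at the same place would move the number beyond the scatter remains open. Also open, from the compounds shown here alone, is whether changes elsewhere on the shared core would produce a step that this place does not.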